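Thiophenyl for trifluoromethylphenyl: notes toward compound 3

The source may report more compounds than this note shows. Statements on the series, on what has been measured and on what is new or still open speak of the compounds shown alone.

Measured so far:
compound 1 `FC(F)(F)c1ccc(C2=NN(C(=S)Nc3ccccc3)C(c3ccc4c(c3)OCCO4)C2)cc1` — 43500 nM
compound 2 `Cc1ccc(C2=NN(C(=S)Nc3ccccc3)C(c3ccc4c(c3)OCCO4)C2)cc1C` — 61300 nM

In a functional assay on A-375 cells (Homo sapiens) for antiproliferative activity, read by MTT assay, with a stated time of 48 h (on this read-out lower numbers stand for stronger inhibition of growth and higher numbers for weaker inhibition of growth), compound 1 gives 43500 nM, the lowest of the two numbers; its nearest neighbour, compound 2, gives 61300 nM. Within the data shown here, the single measured step, a 1.4-fold higher number from compound 1 to compound 2 (0.15 log units; within the scatter), stays within the scatter, so the two aryl groups tried so far on this carbon look interchangeable. Compound 3 `S=C(Nc1ccccc1)N1N=C(c2cccs2)CC1c1ccc2c(c1)OCCO2` differs from compound 1 by thiophen-2-yl in place of 4-(trifluoromethyl)phenyl on a carbon with a double bond to nitrogen. Among the measured compounds shown here, only the step to compound 2 bears on this exchange, and it was flat. No step beyond the scatter is therefore expected. Compound 3 is estimated at 50000 nM with a range from 20000 nM to 125000 nM. The expected step is a 1.1-fold higher number from compound 1 to compound 3 (0.06 log units; within the scatter).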

Compound 3, concentration for 50% growth inhibition: 121000 nM
Compound 3: the middle estimate sits 2.4-fold (0.38 log units) below what was measured, and the stated range covers the measured number.
By their numbers in this assay, from the lowest: compounds 1, 2 and 3 (each within the scatter of the next, the first and the last beyond it).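

Among these compounds, replacing the aryl group on this carbon can move the number: thiophen-2-yl gives a 2.8-fold higher number from compound 1 to compound 3 (0.44 log units; beyond the scatter) as the first step at this position beyond the scatter. The exchange for 3,4-dimethylphenyl gives a 2.0-fold higher number from compound 2 to compound 3 (0.30 log units; within the scatter) and so sets thiophen-2-yl apart only from 4-(trifluoromethyl)phenyl. No measurement at hand explains the step from 4-(trifluoromethyl)phenyl.

Three aryl groups cannot separate the part played by the smaller ring from that of its sulfur. Also open, as far as these compounds go, is whether a phenyl ring carrying an amine or a carboxylic acid on this carbon would lower the number relative to compound 1.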